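Ethyl to Isopropyl on the Sulfonamide Nitrogen

The source may hold more compounds than are shown below. What is called first, only, known or untested is meant among the compounds shown, and "the series" means these compounds.

Compound 2 `CCCCc1ccc(CN(CC)S(C)(=O)=O)c(=O)n1Cc1ccc(-c2ccccc2-c2nn[nH]n2)cc1` is the stronger of the two measured compounds in a functional assay (aorta) for antagonist activity, with Oryctolagus cuniculus as the target (a lower number here means a stronger inhibitor, a higher number a weaker inhibitor), where compound 2 gives 2 nM. Going by the values given here, the only other measured compound, compound 1 `CCCCc1ccc(CN)c(=O)n1Cc1ccc(-c2ccccc2-c2nn[nH]n2)cc1`, gives 20 nM in this assay. Among the compounds with values here, the sole measured step, a 10-fold lower number from compound 1 to compound 2 (1.00 log units; beyond the scatter), comes from replacing the free amino group with an ethyl(methylsulfonyl)amino group. Compound 3 `CCCCc1ccc(CN(C(C)C)S(C)(=O)=O)c(=O)n1Cc1ccc(-c2ccccc2-c2nn[nH]n2)cc1` keeps that group and differs from compound 2 in one place: methyl in place of hydrogen on a saturated chain carbon bound to a saturated chain carbon and a sulfonamide nitrogen, so that the ethyl becomes isopropyl. Within the data shown here, no measured step touches this part of the molecule: the step from compound 1 to compound 2 introduced the sulfonamide, but it says nothing about the size of the alkyl on its nitrogen. With no guiding comparison, and with a change that adds a single carbon, no shift beyond the scatter is expected in this assay. Compound 3 is therefore estimated at 3 nM, within a range of 1 nM to 10 nM, which corresponds to an expected step of a 1.5-fold higher number from compound 2 to compound 3 (0.18 log units; within the scatter).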

Compound 3, half-maximal inhibitory concentration: 0.9 nM
The estimate for compound 3 lay 3.3-fold (0.52 log units) above the measured number; measured number outside the range, below it.
By their numbers in this assay, from the lowest: compound 3; then compound 2; then compound 1.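

In this assay, the alkyl group on the sulfonamide nitrogen turns out to matter: a methyl in place of hydrogen on the saturated chain carbon bound to that nitrogen gives a 2.2-fold lower number from compound 2 to compound 3 (0.35 log units; beyond the scatter), a modest step but one beyond the scatter. This gain comes on top of what the sulfonamide group already brought, so isopropyl(methylsulfonyl)amino in place of amino gives a 22-fold lower number from compound 1 to compound 3 (1.35 log units; beyond the scatter), a large step that leaves compound 3 with the lowest number of the three compounds. Nothing measured alongside these numbers speaks to the reason for this step.

Among the compounds shown, this nitrogen carries only ethyl or isopropyl, so it remains open whether tert-butyl or cyclopropyl there would lower the number further or raise it again. The methyl on the sulfonyl group is the same in compound 2 and compound 3, which leaves open how a larger group at that end, such as phenyl, would read in this assay.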